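Replacing pyridin-3-yl on compound 2 with methoxy

A few compounds are considered here, and "the series" means these few. Any claim that something is new, unique, unknown or untested is made for them only; others in the source may bear on it.

In a functional assay on a cell-free system (plasma, Homo sapiens) for inhibition, with Plasma (Rattus norvegicus) as the target (on this read-out lower numbers stand for stronger inhibition and higher numbers for weaker inhibition), compound 1 (`O=c1cc(N2CCNCC2)oc2ccccc12`) gives 56000 nM and compound 3 (`O=c1cc(N2CCNCC2)c2cc(OCc3cccnc3)ccc2o1`) gives 38000 nM in the same range of high numbers. Compound 2 (`Cc1c(OCc2cccnc2)ccc2c(N3CCNCC3)cc(=O)oc12`) stands lowest of the three at 980 nM with both other numbers beyond the scatter from it. The next change, leading to the unmeasured compound 4 (`COCOc1ccc2c(N3CCNCC3)cc(=O)oc2c1C`), is methoxy in place of pyridin-3-yl on a saturated chain carbon bound to an oxygen on an aromatic ring. Within the data shown here, no single-site step between measured compounds is available to size this change. The expected move in this assay is toward weaker inhibition and beyond the scatter, an estimated 5.1-fold higher number from compound 2 to compound 4 (0.71 log units; beyond the scatter) on thin evidence. Compound 4 is estimated at 5000 nM (expected range 1500 nM to 20000 nM).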

Compound 4, half-maximal inhibitory concentration: 2300 nM
Compound 4: the middle estimate sits 2.2-fold (0.34 log units) above what was measured, within the range that was stated.
By their numbers in this assay, from the lowest: compound 2; then compound 4; then compounds 3 and 1 (each within the scatter of the next).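

In this assay, methoxy in place of pyridin-3-yl on a saturated chain carbon bound to an oxygen on an aromatic ring gives a 2.3-fold higher number from compound 2 to compound 4 (0.37 log units; beyond the scatter) and so costs only a modest part of the inhibition. This place therefore tolerates losing the six-membered aromatic ring from the group, with the step still beyond the scatter. No measurement on hand accounts for this step. On these data alone, whether the step follows the ring itself or its nitrogen stays open. A phenyl or a longer chain at this place would separate the two.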